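Exchange of the aryl group at the double-bonded carbon

This account rests on a few compounds, and the source may have more. Where it says the series, first, only, none or still open, it means among the compounds named here.

Measured compounds:
compound 1, `CN(C)CCn1cnnc1-c1cc(Oc2ccc(NC(=O)N/N=C/c3ccc(Cl)cc3)cc2F)ccn1`: in a functional assay on NCI-H460 cells (Homo sapiens) for cytotoxicity, read by MTT assay, with a stated time of 72 h (a lower number here means a stronger inhibitor, a higher number a weaker inhibitor), compound 1 gives 320 nM
compound 2, `CN(C)CCn1cnnc1-c1cc(Oc2ccc(NC(=O)N/N=C/c3cc(C(C)(C)C)cc(C(C)(C)C)c3O)cc2F)ccn1`: in this assay compound 2 gives 590 nM

Compound 1 holds the lower of the two numbers recorded, but its gap to compound 2 lies within the scatter, so the two are read as equivalent in this assay and no order is drawn between them. Within the data shown here, nothing more is known of the series; no pair of measured compounds differing in a single place exists, so no measured step size is available.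

Compound 3, `CN(C)CCn1cnnc1-c1cc(Oc2ccc(NC(=O)N/N=C/c3cc(Br)c(O)c(Br)c3)cc2F)ccn1`, has not yet been measured. It departs from compound 1 at one place: 3,5-dibromo-4-hydroxyphenyl in place of 4-chlorophenyl on a carbon with a double bond to nitrogen. Among the measured compounds shown here, compound 2 already carries a hydroxyphenyl variant at the same place and sits within the scatter of compound 1, which is the only guide. The step from compound 1 to compound 3 is therefore expected to be a 1.3-fold higher number from compound 1 to compound 3 (0.10 log units; within the scatter), that is, none beyond the scatter. Compound 3 is estimated at 400 nM, with a range from 150 nM to 1200 nM.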

Compound 3, half-maximal inhibitory concentration: 3760 nM
Compound 3: the middle estimate sits 9.4-fold (0.97 log units) below what was measured; measured number outside the range, above it.
By their numbers in this assay, from the lowest: compounds 1 and 2 (each within the scatter of the next); then compound 3.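

In this assay the exchange of 4-chlorophenyl for 3,5-dibromo-4-hydroxyphenyl on a carbon with a double bond to nitrogen gives a 12-fold higher number from compound 1 to compound 3 (1.07 log units; beyond the scatter) and so shows that this place can respond strongly to the aryl group it carries, which compound 1 and compound 2, within the scatter of each other, could not show. A hydroxyphenyl variant does not by itself bring the weaker number: with such a variant in both, compound 2 gives 590 nM and compound 3 gives 3760 nM in this assay on the printed values. No measurement at hand accounts for the step.

The compounds shown leave open whether the two bromine atoms, the hydroxyl or only their combination goes with the step, a question that 3,5-dibromophenyl or 4-hydroxyphenyl at the same carbon would address. Also open, from the compounds shown here alone, is how this place responds to an aryl group bearing an amine or a carboxylic acid.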